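This account rests on a few compounds, and the source may have more. Where it says the series, first, only, none or still open, it means among the compounds named here.

Compound 1: `COc1ccc(S(=O)(=O)N(CC(N)=O)c2ccc(N(CC(N)=O)S(=O)(=O)c3ccc([S+]([O-])CCCCCN=C=S)cc3)c3ccccc23)cc1`, > 10000 nM
Compound 2: `COc1ccc(S(=O)(=O)N(CC(N)=O)c2ccc(N(CC(N)=O)S(=O)(=O)c3ccc([S+]([O-])CCOCCN=C=S)cc3)c3ccccc23)cc1`, > 10000 nM
Compound 3: `COc1ccc(S(=O)(=O)N(CC(N)=O)c2ccc(N(CC(N)=O)S(=O)(=O)c3ccc(S(=O)(=O)CCCCCN=C=S)cc3)c3ccccc23)cc1`, > 10000 nM

In an ADME assay on cells (Peritoneal macrophage, Mus musculus) for cytotoxicity, read by CCK-8 assay, with a stated time of 24 h (a higher number here means that more compound is tolerated, a lower number that less compound is tolerated), compound 1 gives > 10000 nM, which is a limit of the assay and not a number. In this assay compound 2 likewise gives > 10000 nM, again a limit. In this assay compound 3 gives > 10000 nM, also a limit. The change from compound 1 to compound 2 is a group of 6 heavy atoms (3 carbon, 1 nitrogen, 1 oxygen, 1 sulfur; no ring) in place of a group of 6 heavy atoms (4 carbon, 1 nitrogen, 1 sulfur; no ring), on a saturated chain carbon, two bonds along the chain from a sulfur, and the step it made is a step that the two limits leave unreadable from compound 1 to compound 2. The cores of compound 1 and compound 3 differ by a group of 11 heavy atoms (6 carbon, 1 nitrogen, 2 oxygen, 2 sulfur; no ring) in place of a group of 10 heavy atoms (6 carbon, 1 nitrogen, 1 oxygen, 2 sulfur; no ring), on an aromatic carbon. Compound 4, `COc1ccc(S(=O)(=O)N(CC(N)=O)c2ccc(N(CC(N)=O)S(=O)(=O)c3ccc(S(=O)(=O)CCOCCN=C=S)cc3)c3ccccc23)cc1`, is made from compound 3 by a group of 6 heavy atoms (3 carbon, 1 nitrogen, 1 oxygen, 1 sulfur; no ring) in place of a group of 6 heavy atoms (4 carbon, 1 nitrogen, 1 sulfur; no ring), on a saturated chain carbon, two bonds along the chain from a sulfonyl sulfur. This is the same kind of change as that from compound 1 to compound 2, though the surroundings differ: in compound 1 the place is two bonds along the chain from a sulfur, in compound 3 two bonds along the chain from a sulfonyl sulfur. For compound 4 the expected step in this assay is a step that the limit leaves unreadable from compound 3 to compound 4, beside the earlier one, because of the limit of > 10000 nM in this assay, at which 3 of the 3 values shown sit. The estimate for compound 4 in this assay is 15000 nM, between 7000 nM and 40000 nM.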

Compound 4, half-maximal cytotoxic concentration: > 10000 nM
Compound 4: a limit, no number; the forecaster's own chance of this, stated with the estimate: 85%; the middle value does not contradict the limit.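

In this assay compound 4 gives > 10000 nM, which is a limit and not a number. Among these compounds, no step between compound 4 and compound 1, compound 2 or compound 3 can be read, because all of them sit at the same limit: the limit of > 10000 nM in this assay, at which 4 of the 4 values shown sit. The compounds shown leave open whether these four differ at all, and at what concentration any of them reaches its half-maximal cytotoxic effect.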